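This account rests on a few compounds, and the source may have more. Where it says the series, first, only, none or still open, it means among the compounds named here.

Among the measured compounds shown here, compound 1 `Cc1ccnc(NC(c2ccc([N+](=O)[O-])cc2)c2ccc3cccnc3c2O)c1` gives 530 nM in an assay for inhibition of protein disulfide-isomerase (Homo sapiens), with a stated time of 1 h (a higher number here means a weaker inhibitor, a lower number a stronger inhibitor), the second highest of the three numbers so far. Compound 2 `Oc1cc(F)ccc1C(c1ccc2ccoc2c1O)N1CCCCC1` stands nearest with 1070 nM, a higher number beyond the scatter, and compound 3 `Oc1c(C(Nc2ccccc2)c2ccccc2)ccc2cccnc12` stands furthest with 110 nM, the lowest number of the three. Compound 4 `Cc1ccnc(NC(c2cc(C)ccc2C)c2ccc3cccnc3c2O)c1` differs from compound 1 in one place: 2,5-dimethylphenyl in place of 4-nitrophenyl on a saturated chain carbon bound to an aromatic carbon and a nitrogen on an aromatic ring. For the measured compounds named here, no measured pair isolates this change, so the direction rests on little. The shared core appears in compound 3, whose 110 nM shows that lower numbers are reachable, but a step beyond the scatter is not expected here. The expected step is a 1.3-fold lower number from compound 1 to compound 4 (0.12 log units; within the scatter), toward a somewhat lower number. Compound 4 is estimated at 400 nM, with a range from 150 nM to 1200 nM in this assay.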

Compound 4, half-maximal inhibitory concentration: > 40000 nM
Compound 4: a limit, no number (the forecaster's own chance of this, stated with the estimate: 5%); middle value at least 100-fold (2.00 log units) away from the limit.
By their numbers in this assay, from the lowest: compound 3; then compound 1; then compound 2. At a limit, above all of these: compound 4.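

Compound 4 reads as a limit of the assay, not a number: the limit of > 40000 nM in this assay, at which 1 of the 4 values shown sits. In this assay, replacing 4-nitrophenyl with 2,5-dimethylphenyl on the saturated chain carbon gives an at least 75-fold higher number from compound 1 to compound 4 (1.87 log units; beyond the scatter). Among the compounds shown here, this position is therefore far from indifferent to the aryl group it carries, a point no earlier pair isolated.

The compounds shown do not separate the loss of the nitro group from the arrival of the two methyl groups. Going by these compounds, whether a phenyl ring carrying a single methyl or a nitrile would stay near compound 1 remains open.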